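A few compounds are considered here, and "the series" means these few. Any claim that something is new, unique, unknown or untested is made for them only; others in the source may bear on it.

Three measured compounds share one core and differ only in the group carried on the saturated chain carbon bound to an oxygen on a saturated carbon. In an assay on brain for displacement of a labelled ligand from Adrenergic receptor alpha-1 (Rattus norvegicus) (a lower number here means a stronger inhibitor, a higher number a weaker inhibitor), compound 2 `CCCCOCCOC1CCN(c2nc(N)c3cc(OC)c(OC)cc3n2)CC1` gives 1.03 nM. Compound 1 `CCOCCOC1CCN(c2nc(N)c3cc(OC)c(OC)cc3n2)CC1` gives 1.81 nM in this assay, and compound 3 `COc1cc2nc(N3CCC(OCC(C)(C)OC)CC3)nc(N)c2cc1OC` gives 1.14 nM. The step of a 1.8-fold lower number from compound 1 to compound 2 (0.24 log units; within the scatter) and the step of a 1.1-fold higher number from compound 2 to compound 3 (0.04 log units; within the scatter) both stay within the scatter, as does a 1.6-fold lower number from compound 1 to compound 3 (0.20 log units; within the scatter), so the three numbers cannot be told apart.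

Compound 4 `CCOC(C)(COC1CCN(c2nc(N)c3cc(OC)c(OC)cc3n2)CC1)c1ccccc1` has not been measured in this assay. Its change from compound 2 is 1-ethoxy-1-phenylethyl in place of butoxymethyl on a saturated chain carbon bound to an oxygen on a saturated carbon. Among the compounds with values here, the steps that bear on this are a 1.1-fold higher number from compound 2 to compound 3 (0.04 log units; within the scatter) and a 1.6-fold lower number from compound 1 to compound 3 (0.20 log units; within the scatter), both of which swap groups at the same place and both of which stayed within the scatter. The entering group is larger than anything tried before, so the expectation rests on a thin base, but no step beyond the scatter is expected here. Compound 4 is therefore estimated at 1.6 nM, with a range from 0.5 nM to 5 nM, which means an expected step of a 1.6-fold higher number from compound 2 to compound 4 (0.19 log units; within the scatter).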

Compound 4, inhibition constant: 0.15 nM
Estimate against measurement, compound 4: 11-fold (1.03 log units) above; measured number outside the range, below it.
By their numbers in this assay, from the lowest: compound 4; then compounds 2, 3 and 1 (each within the scatter of the next).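

At the saturated chain carbon bound to an oxygen on a saturated carbon, the earlier swaps had produced no step beyond the scatter, so this place could have seemed indifferent to the group it carries. In this assay 1-ethoxy-1-phenylethyl, with its six-membered aromatic ring of carbon only, changes that picture, giving all three steps beyond the scatter (modest for a 6.9-fold lower number from compound 2 to compound 4 (0.84 log units; beyond the scatter) and for a 7.6-fold lower number from compound 3 to compound 4 (0.88 log units; beyond the scatter) and large for a 12-fold lower number from compound 1 to compound 4 (1.08 log units; beyond the scatter)) and placing compound 4 clearly lowest of the four. No measurement at hand accounts for these steps.

The compounds shown do not separate the aromatic ring from the rest of the entering group, so a plain benzyl group at this place remains an open test. As far as these compounds go, how a pyridine ring or an amine in place of that ring would read in this assay also stays open.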